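The source may hold more compounds than are shown below. What is called first, only, known or untested is meant among the compounds shown, and "the series" means these compounds.

Three compounds with a shared core, an acrylamide joined to an aryl sulfonamide, have been tested in a functional assay on B16-F10 cells (Mus musculus) for antiproliferative activity, read by ELISA and MTT assay, with a stated time of 48 h; a higher number here means a weaker inhibitor, a lower number a stronger inhibitor. Compound 1 `Cc1ccc(S(=O)(=O)NC(=O)/C=C/c2ccccc2)cc1` gives 13.8 ug/mL and has the highest number of the three; compound 3 `COc1ccc(/C=C/C(=O)NS(=O)(=O)c2ccc(C)cc2)cc1` gives 12.2 ug/mL, and compound 2 `O=C(/C=C/c1ccccc1)NS(=O)(=O)c1ccc(Br)cc1` gives 3.9 ug/mL. Two single changes have been measured from compound 1. Swapping a group on the sulfonyl-bearing ring gave a 3.5-fold lower number from compound 1 to compound 2 (0.55 log units; beyond the scatter), a modest gain in potency. Adding a group to the ring that carries the double bond gave a 1.1-fold lower number from compound 1 to compound 3 (0.05 log units; within the scatter), no real difference.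

Compound 4 `Cc1ccc(S(=O)(=O)NC(=O)/C=C/c2ccccc2[N+](=O)[O-])cc1` differs from compound 1 in one place: nitro in place of hydrogen on an aromatic carbon. This new group sits on the same ring that was changed in compound 3, so the step from compound 1 to compound 3 is the closer guide, and it showed nothing beyond the usual scatter. The step from compound 1 to compound 2 concerns the other ring and bears less on this case. The expectation for compound 4 is therefore a step of about a 1.2-fold lower number from compound 1 to compound 4 (0.06 log units; within the scatter), that is, no change that can be told from repeat-to-repeat noise. Compound 4 is estimated to give 12 ug/mL in this assay, within a range from 6 ug/mL to 25 ug/mL.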

Compound 4, half-maximal inhibitory concentration: 10.3 ug/mL
For compound 4 the middle estimate is 1.2-fold (0.07 log units) above the measured one; low and high end bracket the measured number.
By their numbers in this assay, from the lowest: compound 2; then compounds 4, 3 and 1 (each within the scatter of the next).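

In this assay, nitro in place of hydrogen gives a 1.3-fold lower number from compound 1 to compound 4 (0.13 log units; within the scatter), so this group, ortho to a large group on the ring that carries the double bond, leaves the number indistinguishable from that of compound 1. With compound 3, this makes two different additions to that ring whose steps from compound 1 stay within the scatter, while the only step beyond it, a 3.5-fold lower number from compound 1 to compound 2 (0.55 log units; beyond the scatter), is the swap on the sulfonyl-bearing ring; among these few compounds, the ring that carries the double bond has so far tolerated substitution without a readable shift in either direction. No measurement is available here that would explain this result, such as one on how the nitro group alters the molecule.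

The compounds shown leave open whether an amine or a carboxylic acid at this same place, ortho to a large group, would also stay within the scatter or would move the number clearly up or down. They also leave open whether nitro at another carbon of this ring would behave as it does here, and whether the bromo group of compound 2 would keep its gain with a nitro group on the other ring.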